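A few compounds are considered here, and "the series" means these few. Any claim that something is new, unique, unknown or untested is made for them only; others in the source may bear on it.

Compound 1, `CCCCCCNC(=O)[C@H]1OC(n2cnc3c(N)ncnc32)[C@H](O)[C@@H]1O`, gives 19 nM in an assay on cell membranes for binding affinity to 2-oxoglutarate receptor 1 (Rattus norvegicus), read by radioligand binding; on this read-out higher numbers stand for weaker inhibition and lower numbers for stronger inhibition.
Compound 2, `NCCCCCCCCNC(=O)[C@H]1OC(n2cnc3c(N)ncnc32)[C@H](O)[C@@H]1O`, gives 29 nM in this assay.
Compound 3, `CC(=O)NCCCCCCCCNC(=O)[C@H]1OC(n2cnc3c(N)ncnc32)[C@H](O)[C@@H]1O`, gives 10 nM in this assay.

Compound 2 holds the highest of the three numbers. Within the data shown here, compound 1 sits nearest to it, separated by a 1.5-fold higher number from compound 1 to compound 2 (0.18 log units; within the scatter), and compound 3 sits furthest, separated by a 2.9-fold lower number from compound 2 to compound 3 (0.46 log units; beyond the scatter), the only step among the three that reaches beyond the scatter. Compound 1 and compound 3 are separated by a 1.9-fold lower number from compound 1 to compound 3 (0.28 log units; within the scatter).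

Compound 4, `CC(C)CONC(=O)[C@H]1OC(n2cnc3c(N)ncnc32)[C@H](O)[C@@H]1O`, differs from compound 2 in isobutoxy in place of 8-aminooctyl on an amide-type nitrogen. Among the measured compounds shown here, no measured step covers this kind of change. The steps from compound 1 to compound 2 and from compound 1 to compound 3 extend the chain, and the step from compound 2 to compound 3 alters the amine nitrogen; all three keep a long chain on the amide-type nitrogen, and all three moved the number only a little. For the measured compounds named here, in compound 4 the chain itself is removed and an isobutoxy group takes its place, which no measured pair tests. The expectation is therefore uncertain, leaning towards a higher number. The estimate for compound 4 is 60 nM, with a range from 10 nM to 400 nM, an expected step of a 2.1-fold higher number from compound 2 to compound 4 (0.32 log units; beyond the scatter).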

Compound 4, inhibition constant: 20 nM
Compound 4: the middle estimate sits 3.0-fold (0.48 log units) above what was measured, and the stated range covers the measured number.
By their numbers in this assay, from the lowest: compounds 3, 1, 4 and 2 (each within the scatter of the next, the first and the last beyond it).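

On the amide-type nitrogen, isobutoxy in place of 8-aminooctyl gives a 1.5-fold lower number from compound 2 to compound 4 (0.16 log units; within the scatter), and isobutoxy in place of hexyl gives a 1.1-fold higher number from compound 1 to compound 4 (0.02 log units; within the scatter). So in this assay this position, which carried only straight chains in the earlier compounds, also tolerates a much smaller branched group with an oxygen in it: isobutoxy has 5 heavy atoms against 9 for 8-aminooctyl, yet neither step goes beyond the scatter. Nothing available explains why these different groups read so alike.

Isobutoxy differs from hexyl in length, branching and the oxygen all at once, so the contribution of each stays unknown; a plain butyl or a straight butoxy chain would help separate them. Also open, as far as these compounds go, is how small the group can get, for example methoxy or a lone methyl, before the number shifts.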